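The source may report more compounds than this note shows. Statements on the series, on what has been measured and on what is new or still open speak of the compounds shown alone.

Working notes on the thioether and ether cores

Compound 1 `NC1=NC2(CCSCC2)N(OCCCOc2ccc(Cl)c(Cl)c2)C(N)=N1` is the reference point. In a functional assay on HL-60 cells (Homo sapiens) for antiproliferative activity, read by MTT assay, with a stated time of 72 h (a higher number here means a weaker inhibitor, a lower number a stronger inhibitor), compound 1 gives 140 nM. Among the measured compounds shown here, compound 2 `NC1=NC2(CCSCC2)N(OCCCOc2cc(Cl)c(Cl)cc2Cl)C(N)=N1` carries the change (chloro in place of hydrogen on an aromatic carbon); in this assay compound 2 gives 730 nM, and the step of a 5.2-fold higher number from compound 1 to compound 2 (0.72 log units; beyond the scatter) is the only measured instance of this change so far.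

Compound 3 `NC1=NC2(CCOCC2)N(OCCCOc2ccc(Cl)c(Cl)c2)C(N)=N1` has a different core; the difference between the core of compound 3 and the core of compound 1 is not broken down here. In this assay compound 3 gives 1240 nM, which stands close to the value of compound 2 and well apart from the value of compound 1.

Compound 4 `NC1=NC2(CCOCC2)N(OCCCOc2cc(Cl)c(Cl)cc2Cl)C(N)=N1` is not yet measured. For the measured compounds named here, it differs from compound 3 by chloro in place of hydrogen on an aromatic carbon, which is the same change as the one from compound 1 to compound 2, at a place described in the same words. Going by the values given here, the expectation for compound 4 therefore rests on compound 1 and compound 2, whose step a 5.2-fold higher number from compound 1 to compound 2 (0.72 log units; beyond the scatter) is the only guide, transferred onto the core of compound 3. For compound 4 the step of a 4.4-fold higher number from compound 3 to compound 4 (0.65 log units; beyond the scatter) is expected in this assay, allowing that a change may not carry identically across the two cores. Compound 4 is thus estimated at 5500 nM in this assay, with an expected range from 2000 nM to 15000 nM.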

Compound 4, half-maximal inhibitory concentration: 2360 nM
Compound 4: middle estimate off by 2.3-fold (0.37 log units), on the high side; low and high end bracket the measured number.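

On the core of compound 3, the change from 3,4-dichlorophenyl to 2,4,5-trichlorophenyl gives in this assay a 1.9-fold higher number from compound 3 to compound 4 (0.28 log units; within the scatter), so on this core the effect of the added chloro is not resolved from the scatter. The size of the step therefore does not carry unchanged from the core of compound 1 to the core of compound 3: the same change on two cores in this assay, a 5.2-fold higher number (0.72 log units; beyond the scatter) from compound 1 to compound 2 and a 1.9-fold higher number (0.28 log units; within the scatter) from compound 3 to compound 4, 2.7-fold (0.44 log units) apart, beyond the scatter of two such steps. This rests on one matched pair per core, so it shows that the step can depend on the core but gives no general rule for the series, does not establish a direction for the change on the core of compound 3, and does not identify what in the two cores accounts for the gap.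

The compounds shown leave open how the same step behaves with an amine in place of the ring sulfur or oxygen of the core, and whether a longer chain between the core and the aromatic ring alters it. Also open, going by these compounds, is whether fluoro or methoxy entering at the same aromatic carbon would follow the chloro step on either core.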